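The source may report more compounds than this note shows. Statements on the series, on what has been measured and on what is new or still open speak of the compounds shown alone.

Measured so far:
compound 1, `Cc1ccc(S(=O)(=O)NNC(=O)COc2ccc3cc(C(O)(C(F)(F)F)C(F)(F)F)c(O)cc3c2)cc1` — 16100 nM
compound 2, `O=C(COc1ccc2cc(C(O)(C(F)(F)F)C(F)(F)F)c(O)cc2c1)NCc1ccccc1` — > 20000 nM

Both share one core and differ only at the amide-type nitrogen. In an assay on isolated protein for inhibition of receptor-type tyrosine-protein phosphatase C (Homo sapiens), read by spectrophotometry (a lower number here means a stronger inhibitor, a higher number a weaker inhibitor), compound 1 gives 16100 nM. For compound 2 this assay reports only a limit, > 20000 nM. Compound 2 therefore stands at the limit described in the limit of > 20000 nM in this assay, at which 1 of the 2 values shown sits, and its gap to compound 1 is not resolved beyond the scatter. Within the data shown here, the one measured step at that nitrogen, an at least 1.2-fold higher number from compound 1 to compound 2 (0.09 log units; that floor lies within the scatter), is small.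

Compound 3, `CC(C)c1ccc(NC(=O)COc2ccc3cc(C(O)(C(F)(F)F)C(F)(F)F)c(O)cc3c2)cc1`, carries 4-isopropylphenyl in place of benzyl on an amide-type nitrogen. Among the measured compounds shown here, the single comparison at this position gives no sign of a large move in either direction, so no step beyond the scatter is expected, and the result may again be a limit. Compound 3 is expected to show 25000 nM, range 8000 nM to 80000 nM. The expected step that the limit leaves unreadable from compound 2 to compound 3 lies within the scatter.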

Compound 3, half-maximal inhibitory concentration: 7800 nM
Estimate against measurement, compound 3: 3.2-fold (0.51 log units) above; the measured number lies below the stated range.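

In this assay the amide-type nitrogen now gives a first clear move: 4-isopropylphenyl in place of benzyl produces an at least 2.5-fold lower number from compound 2 to compound 3 (0.40 log units; beyond the scatter), so this position does respond to the group it carries. Set against the ((4-methylphenyl)sulfonyl)amino group, the same 4-isopropylphenyl gives a 2.1-fold lower number from compound 1 to compound 3 (0.31 log units; beyond the scatter), which makes compound 3 the strongest inhibitor of the three shown. The first of these steps is only a floor, since the value of compound 2 is a limit and not a number: the limit of > 20000 nM in this assay, at which 1 of the 3 values shown sits.

The change from benzyl to 4-isopropylphenyl removes the carbon link to the ring and adds the isopropyl group at once, so the compounds shown do not separate the two. From the compounds shown here alone, how an amine or a carboxylic acid in place of the isopropyl group would read in this assay also stays open.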